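Ester Branching Across Two Cyclic Urea Cores

This account rests on a few compounds, and the source may have more. Where it says the series, first, only, none or still open, it means among the compounds named here.

Compound 1 `CC1=C(C(=O)OCC(C)C)C(c2ccoc2)NC(=O)N1` carries an isobutyl ester; in an assay on membranes from HeLa cells for displacement of a labelled ligand from adenosine receptor A3 (Homo sapiens), read by scintillation counting, with a stated time of 180 min, tested at 1 uM (on this read-out lower numbers stand for less inhibition and higher numbers for more inhibition at the one concentration tested (going by the name of the read-out)), compound 1 gives 16%. Compound 2 `CC1=C(C(=O)OC(C)(C)C)C(c2ccoc2)NC(=O)N1` differs from it by tert-butyl in place of isobutyl on an oxygen next to a carbonyl group, and in this assay compound 2 gives 2%. Among the compounds with values here, that pair supplies the only measured step for this change: a number 14 percentage points lower from compound 1 to compound 2 (beyond the scatter). Compound 3 `CC1=C(C(=O)OCC(C)C)C(c2ccsc2)NC(=O)N1C` rests on a different core; the difference between the core of compound 3 and the core of compound 1 is not broken down here. In this assay compound 3 gives 4%, a number within the scatter of compound 2, while its gap to compound 1 lies beyond the scatter. Compound 4 `CC1=C(C(=O)OC(C)(C)C)C(c2ccsc2)NC(=O)N1C` is not yet measured; it differs from compound 3 by tert-butyl in place of isobutyl on an oxygen next to a carbonyl group, the same change as that made between compound 1 and compound 2, at a place described in the same words. Compound 3 already sits near the bottom of the read-out, so little room remains downward. The step is expected to be a number 4 percentage points lower from compound 3 to compound 4 (within the scatter), modest and bounded by the floor, resting on a number 14 percentage points lower from compound 1 to compound 2 (beyond the scatter). Compound 4 is therefore estimated at 0% in this assay, between -8% and 8%.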

Compound 4, a percentage reported as inhibition, at one concentration (the size of the read-out at that concentration, not a potency): 14%
Beside the measured number, compound 4's estimate is 14 percentage points below it; measured number above the stated range.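

In this assay, within the data shown here, tert-butyl in place of isobutyl on an oxygen next to a carbonyl group gives a number 10 percentage points higher from compound 3 to compound 4 (within the scatter), so on the core of compound 3 the change produces no step that stands clear of repeated measurement. Set beside the earlier step, the change does not carry over at the same size from one core to the other: the same change on two cores in this assay, a number 14 percentage points lower (beyond the scatter) from compound 1 to compound 2 and a number 10 percentage points higher (within the scatter) from compound 3 to compound 4, 24 percentage points apart, beyond the scatter of two such steps This shows that a step read on the core of compound 1 cannot simply be transferred to the core of compound 3, but it rests on a single pair per core and does not show that the change truly reverses direction, since the new step lies within the scatter.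

The compounds shown leave open which of the differences between the two cores separates the steps, as those differences are not taken apart one at a time. Also open, on these data alone, is how a benzyl ester, a longer chain such as hexyl, or a carboxylic acid would read at this place.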